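This account rests on a few compounds, and the source may have more. Where it says the series, first, only, none or still open, it means among the compounds named here.

Compound 1 `Cc1cccc(C(=O)Nc2ccc3c(c2)CC(NS(=O)(=O)c2ccccc2)C3)c1-c1ccc(F)cc1` sets the reference point of this small set. In an assay for inhibition of apolipoprotein B-100 (Homo sapiens), tested at 100 nM (a lower number here means a stronger inhibitor, a higher number a weaker inhibitor), compound 1 gives 1.2 nM. Compound 2 `Cc1cccc(C(=O)Nc2ccc3c(c2)CC(NS(=O)(=O)c2ccccc2)C3)c1-c1ccc(Cl)cc1` is the same molecule with the change (chloro in place of fluoro on an aromatic carbon), and in this assay compound 2 gives 2.4 nM; the measured step is a 2.0-fold higher number from compound 1 to compound 2 (0.30 log units; within the scatter). Compound 3 `Cc1cccc(C(=O)Nc2ccc3c(c2)CC(NS(=O)(=O)c2cccs2)C3)c1-c1ccc(F)cc1` differs from compound 1 in its core by thiophen-2-yl in place of phenyl on a sulfonyl sulfur, and in this assay compound 3 gives 1.4 nM, so that the step of a 1.2-fold higher number from compound 1 to compound 3 (0.07 log units; within the scatter) also stays inside the scatter. Compound 4 `Cc1cccc(C(=O)Nc2ccc3c(c2)CC(NS(=O)(=O)c2cccs2)C3)c1-c1ccc(Cl)cc1` is not yet measured in this assay. It differs from compound 3 by chloro in place of fluoro on an aromatic carbon, which is the same change as that from compound 1 to compound 2, made on the core of compound 3 rather than that of compound 1. Since the same change on the other core gave a 2.0-fold higher number from compound 1 to compound 2 (0.30 log units; within the scatter), compound 4 is expected to stand about a 2.0-fold higher number from compound 3 to compound 4 (0.30 log units; within the scatter) from compound 3, a step that would still lie within the usual scatter. On that basis compound 4 is estimated at 2.8 nM in this assay, with a plausible range from 1.4 nM to 5.6 nM.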

Compound 4, half-maximal inhibitory concentration: 3 nM
Beside the measured number, compound 4's estimate is 1.1-fold (0.03 log units) below it; the range from low to high includes it.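

In this assay, 4-chlorophenyl in place of 4-fluorophenyl on the core of compound 3 gives a 2.1-fold higher number from compound 3 to compound 4 (0.33 log units; beyond the scatter), and this step agrees with the one seen for the same change on the core of compound 1: the same change on two cores in this assay, a 2.0-fold higher number (0.30 log units; within the scatter) from compound 1 to compound 2 and a 2.1-fold higher number (0.33 log units; beyond the scatter) from compound 3 to compound 4, 1.1-fold (0.03 log units) apart, within the scatter of two such steps. Read the other way round, thiophen-2-yl in place of phenyl on the sulfonyl sulfur gives a 1.3-fold higher number from compound 2 to compound 4 (0.10 log units; within the scatter), and this too agrees with the earlier step: the same change on two cores in this assay, a 1.2-fold higher number (0.07 log units; within the scatter) from compound 1 to compound 3 and a 1.3-fold higher number (0.10 log units; within the scatter) from compound 2 to compound 4, 1.1-fold (0.03 log units) apart, within the scatter of two such steps. This shows that each change carried over between these two cores with its size intact, but it rests on a single square of four compounds, with small steps, and does not show that the same would hold on any other core or explain why the steps agree.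

The compounds shown leave open how a bromo or a methoxy group in the place of the chloro would read. They also leave open whether a propyl chain or a pyridine ring on the sulfonyl sulfur would carry over in the same way.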